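This account rests on a few compounds, and the source may have more. Where it says the series, first, only, none or still open, it means among the compounds named here.

Measured so far:
compound 1, `Cc1cc(=O)n(-c2ccc(F)c(F)c2)nc1C(=O)Nc1ccc(Oc2ncnc3ccsc23)cc1`: 8180 nM
compound 2, `Cc1cc(=O)n(-c2cccc(F)c2)nc1C(=O)Nc1ccc(Oc2ncnc3sccc23)cc1`: 16400 nM

In a functional assay on A549 cells (Homo sapiens) for cytotoxicity, read by MTT assay, with a stated time of 72 h (a higher number here means a weaker inhibitor, a lower number a stronger inhibitor), compound 2 gives 16400 nM and compound 1 gives 8180 nM; the two values lie within the usual scatter of each other, so nothing separates them on the numbers available. The pair also differs in two places at once, the bicyclic core and the fluorine pattern of the aryl on the pyridazinone, so neither value says anything on its own about either change.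

Compound 3, `Cc1cc(=O)n(-c2ccc(F)c(F)c2)nc1C(=O)Nc1ccc(Oc2ncnc3sccc23)cc1`, keeps the core of compound 2 and carries the aryl of compound 1. Against compound 2 the change is fluoro in place of hydrogen on an aromatic carbon. For the measured compounds named here, no measured pair isolates this change. Both known values sit close together in this assay, and the step from compound 2 to compound 3 is expected to be small, in either direction, and not beyond the scatter. The value of compound 3 in this assay is estimated at 12000 nM, with a range of 5000 nM to 30000 nM, meaning an expected step of a 1.4-fold lower number from compound 2 to compound 3 (0.14 log units; within the scatter).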

Compound 3, half-maximal inhibitory concentration: 13500 nM
The estimate for compound 3 lay 1.1-fold (0.05 log units) below the measured number, within the range that was stated.
By their numbers in this assay, from the lowest: compounds 1, 3 and 2 (each within the scatter of the next).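

In this assay, going from 3-fluorophenyl to 3,4-difluorophenyl on the core of compound 2 gives a step (a 1.2-fold lower number from compound 2 to compound 3 (0.08 log units; within the scatter)) that does not separate the two compounds. For the compounds shown here, this is the first reading of this change alone: the added fluoro group sits on an aromatic carbon, ortho to a fluoro group and para to a large group, and at this position it leaves the two values indistinguishable. Going by these compounds alone, with the 3,4-difluorophenyl group held constant, exchanging the core of compound 1 for the core of compound 3, two groups with the same count of heavy atoms, also stays within the scatter (a 1.7-fold higher number from compound 1 to compound 3 (0.22 log units; within the scatter)), so neither of the two differences mixed together in the first pair separates the compounds on its own. Nothing available on these compounds beyond the cell values bears on the result.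

Still open, as far as these compounds go, is whether a chloro, methoxy or amine group on the same aromatic carbon would move the value beyond the scatter. Also open, from the compounds shown here alone, is what replacing the methyl group on the pyridazinone with a carboxylic acid or a longer chain would do in this assay.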